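Swapping the aryl group on a urea-linked pyrazine series

A few compounds are considered here, and "the series" means these few. Any claim that something is new, unique, unknown or untested is made for them only; others in the source may bear on it.

Measured compounds:
compound 1, `Cc1ccc(NC(=O)Nc2cccc(CNc3nccnc3Cl)c2)cc1`, 11900 nM
compound 2, `Cc1ccc(NC(=O)Nc2cccc(CNc3nccnc3Cl)c2)cc1Cl`, 17500 nM
compound 3, `CC(C)(C)c1ccc(NC(=O)Nc2cccc(CNc3nccnc3Cl)c2)cc1`, 4820 nM

These three share one core and differ only in the aryl group attached to the urea. In a functional assay on MGC-803 cells (Homo sapiens) for antiproliferative activity, read by MTT assay, with a stated time of 48 h (on this read-out lower numbers stand for stronger inhibition and higher numbers for weaker inhibition), compound 2 gives the highest of the three numbers. Its nearest neighbour is compound 1, with a 1.5-fold higher number from compound 1 to compound 2 (0.17 log units; within the scatter) separating them, so the two cannot be told apart. Compound 3 lies furthest away: the change to it, a 2.5-fold lower number from compound 1 to compound 3 (0.39 log units; beyond the scatter), is a modest but real gain in inhibition.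

Compound 4, `Cc1ccc(NC(=O)Nc2cccc(CNc3nccnc3Cl)c2)c(C)c1`, has not yet been tested. Compared with compound 2 the change is:

2,4-dimethylphenyl in place of 3-chloro-4-methylphenyl on an amide-type nitrogen

Among the measured compounds shown here, no measured step repeats this exact exchange. The closest guidance comes from the two known steps: adding a chloro on the aryl ring barely moved the number, while enlarging methyl to tert-butyl helped modestly. Compound 4 keeps the 4-methyl, drops the chloro and adds a second methyl, so the expectation is a number close to that of compound 1, with a 1.5-fold lower number from compound 2 to compound 4 (0.16 log units; within the scatter) as the estimated step. The estimate for compound 4 in this assay is therefore 12000 nM, within a range of 5000 nM to 30000 nM.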

Compound 4, half-maximal inhibitory concentration: 10100 nM
For compound 4 the middle estimate is 1.2-fold (0.07 log units) above the measured one; measured number inside the range.
By their numbers in this assay, from the lowest: compound 3; then compounds 4, 1 and 2 (each within the scatter of the next).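

In this assay, a further methyl on the aryl ring gives a 1.2-fold lower number from compound 1 to compound 4 (0.07 log units; within the scatter) and so adds no readable effect, which shows that this aryl ring can carry a further methyl without a measurable loss or gain. The full exchange of 3-chloro-4-methylphenyl for 2,4-dimethylphenyl on the amide-type nitrogen gives a 1.7-fold lower number from compound 2 to compound 4 (0.24 log units; within the scatter) and also stays within the scatter, so a chlorine-bearing aryl group and an all-carbon one cannot be told apart here, and compounds 1, 2 and 4 read as a single level of weak activity in this small set. No measurement shown here explains why these three aryl groups read alike.

Among the changes shown, only the tert-butyl group of compound 3 gives a step beyond the scatter, so it remains open whether other groups in place of the 4-methyl, such as a longer chain like n-butyl or a methoxy group, would also lower the number. Going by these compounds, it is equally open how a group such as a carboxylic acid or an amine would behave on this ring.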